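A few compounds are considered here, and "the series" means these few. Any claim that something is new, unique, unknown or untested is made for them only; others in the source may bear on it.

Three compounds have numbers in a functional assay on CHO-K1 cells for agonist activity at Glucose-dependent insulinotropic receptor (Homo sapiens), read by HTRF and cAMP accumulation, with a stated time of 30 min; a higher number here means that more compound is needed for the effect, a lower number that less compound is needed. Compound 1 `CC(C)(C)OC(=O)N1CCC(CCCNc2ccc3c(c2)CCC3=O)CC1` gives 86 nM. Compound 2 `CC(C)(C)OC(=O)N1CCC(CCCNc2ccc3c(c2)C(=O)CCO3)CC1` gives 272 nM. Compound 3 `COc1cnc(N2CCC(CCCNc3ccc4c(c3)OCC4=O)CC2)nc1` gives 115 nM. Compound 3 stands second highest of the three numbers: compound 1 is its nearest neighbour, at a gap within the scatter, whereas compound 2 lies beyond the scatter from it. Compound 4 `CC(C)c1nnc(N2CCC(CCCNc3ccc4c(c3)OCC4=O)CC2)o1` is not yet measured; it differs from compound 3 by 5-isopropyl-1,3,4-oxadiazol-2-yl in place of 5-methoxypyrimidin-2-yl on an amine nitrogen in a ring, the core of compound 3 being kept and only the group on the amine nitrogen in a ring exchanged. Going by the values given here, no measured pair shows a change of this kind, so its step size is unknown from the series. In this assay the expected step is a 1.1-fold higher number from compound 3 to compound 4 (0.05 log units; within the scatter), not beyond the scatter in either direction. Compound 4 is estimated at 130 nM, with a range from 40 nM to 450 nM.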

Compound 4, half-maximal effective concentration: 704 nM
For compound 4 the middle estimate is 5.4-fold (0.73 log units) below the measured one, outside the stated range (above it).
By their numbers in this assay, from the lowest: compounds 1 and 3 (each within the scatter of the next); then compound 2; then compound 4.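

The group on the amine nitrogen in a ring now has its first readable step: in this assay, 5-isopropyl-1,3,4-oxadiazol-2-yl in place of 5-methoxypyrimidin-2-yl gives a 6.1-fold higher number from compound 3 to compound 4 (0.79 log units; beyond the scatter). The two groups have the same heavy-atom, donor and acceptor counts, so these counts do not separate them, whereas the ring size and the substituent both differ. Nothing available accounts for the step.

Going by these compounds, whether the step follows the ring or its substituent remains open. A 5-isopropylpyrimidin-2-yl or 5-methoxy-1,3,4-oxadiazol-2-yl group on the same nitrogen would separate the two.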